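From Dimethoxyphenyl to Fluorophenyl on the Amide Carbonyl

The compounds below may be only part of what the source reports. "The series", "measured", "known", "first", "only" and "open" are said of these compounds alone.

Compound 1, `COc1ccc(C(=O)Nc2ccc(C(=O)/C=C/c3nc(C)c(C)nc3C)cc2)cc1OC`, gives 1660 nM in a functional assay on MCF7 cells (Homo sapiens) for antiproliferative activity, read by CCK-8 assay, with a stated time of 72 h; on this read-out lower numbers stand for stronger inhibition and higher numbers for weaker inhibition.
Compound 2, `COc1cccc(OC)c1C(=O)Nc1ccc(C(=O)/C=C/c2nc(C)c(C)nc2C)cc1`, gives 2470 nM in this assay.

Going by the values given here, compound 2 holds the highest of the two numbers measured so far; its nearest neighbour is compound 1, and the step of a 1.5-fold higher number from compound 1 to compound 2 (0.17 log units; within the scatter) separates them, so the two values cannot be ordered against each other. The next compound, compound 3, `Cc1nc(C)c(/C=C/C(=O)c2ccc(NC(=O)c3ccc(F)cc3)cc2)nc1C`, is obtained from compound 2 through the change (4-fluorophenyl in place of 2,6-dimethoxyphenyl on a carbonyl carbon). Among the compounds with values here, the only measured step, a 1.5-fold higher number from compound 1 to compound 2 (0.17 log units; within the scatter), also sits on the same carbonyl carbon, where one substituted phenyl was traded for another without a change beyond the scatter. That step says nothing specific about a 4-fluorophenyl, so the basis for expectation is thin. On this evidence compound 3 is expected to stay near compound 2 in this assay, with a step of a 1.0-fold higher number from compound 2 to compound 3 (0.01 log units; within the scatter), and the value of compound 3 is estimated at 2500 nM, within a range from 800 nM to 8000 nM.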

Compound 3, half-maximal inhibitory concentration: 1540 nM
Compound 3: the middle estimate sits 1.6-fold (0.21 log units) above what was measured; low and high end bracket the measured number.
By their numbers in this assay, from the lowest: compounds 3, 1 and 2 (each within the scatter of the next).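

Exchanging the 2,6-dimethoxyphenyl for 4-fluorophenyl gives a 1.6-fold lower number from compound 2 to compound 3 (0.21 log units; within the scatter) and exchanging the 3,4-dimethoxyphenyl for the same group gives a 1.1-fold lower number from compound 1 to compound 3 (0.03 log units; within the scatter) so in this assay the three compounds cannot be ordered, whichever dimethoxyphenyl serves as the comparison. Going by these compounds alone, until now, the only step at this carbonyl carbon, whose other neighbour is an amide-type nitrogen, had traded one dimethoxyphenyl for another; the new result shows the same absence of a readable difference when the entering group has fewer heavy atoms than the group it replaces, carries fluorine instead of oxygen, and has 0 hydrogen-bond acceptors instead of 2. No measurement at hand bears on what lies behind this result.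

From the compounds shown here alone, all three compounds carry a substituted phenyl on this carbonyl carbon, so it remains open whether a group without that ring, such as a longer alkyl chain, would give a number beyond the scatter. Going by these compounds, it is equally open whether a phenyl bearing an amine or a carboxylic acid would read differently from the dimethoxyphenyl and 4-fluorophenyl groups.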